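A few compounds are considered here, and "the series" means these few. Any claim that something is new, unique, unknown or untested is made for them only; others in the source may bear on it.

Compounds measured so far in an ADME assay on HUVEC cells (Homo sapiens) for antiproliferative activity, read by MTT assay, with a stated time of 48 h; a higher number here means a weaker inhibitor, a lower number a stronger inhibitor:

Compound 1, `N#CC1=C(N)Oc2c(c3nc4ccccc4nc3c3ccccc23)C12C(=O)N(Cc1cnnn1-c1ccc(Cl)cc1)c1ccccc12`. In this assay compound 1 gives only a limit, > 50000 nM.
Compound 2, `COc1ccccc1-n1nncc1CN1C(=O)C2(C(C#N)=C(N)Oc3c2c2nc4ccccc4nc2c2ccccc32)c2ccccc21`. In this assay compound 2 gives only a limit, > 50000 nM.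
Compound 3, `Cc1cccc(-n2nncc2CN2C(=O)C3(C(C#N)=C(N)Oc4c(N)cc5nc6ccccc6nc5c43)c3ccccc32)c1`. In this assay compound 3 gives only a limit, > 50000 nM.

Compound 3 thus stands at the limit, as do the two other values shown, all sitting at the limit of > 50000 nM in this assay, at which 3 of the 3 values shown sit. Compound 4, `N#CC1=C(N)Oc2c(N)cc3nc4ccccc4nc3c2C12C(=O)N(Cc1cnnn1-c1ccccc1Cl)c1ccccc12`, differs from compound 3 by 2-chlorophenyl in place of 3-methylphenyl on an aromatic nitrogen. Going by the values given here, the only step that bears on a change of the aryl group on the triazole nitrogen is a step that the two limits leave unreadable from compound 1 to compound 2, and that step is itself unreadable because both ends are limits. No step beyond the scatter is therefore expected; compound 4 is estimated to remain at the limit as well, with an expected change of a step that the limit leaves unreadable from compound 3 to compound 4. The estimate for compound 4 is 100000 nM, in the range 50000 nM to 300000 nM.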

Compound 4, half-maximal inhibitory concentration: > 50000 nM
Compound 4: only a limit was reported; the forecaster's own chance of this, stated with the estimate: 85%; the middle value is on the limit's open side.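

Going by these compounds alone, compound 3 and compound 4 both give only limits, so no step between them can be read. The compounds shown leave open whether any aryl group on the triazole nitrogen alters the result in this assay, as every value stands at one limit: the limit of > 50000 nM in this assay, at which 4 of the 4 values shown sit.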